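A Halogenated Aryl Swap on a Triterpene Triazole Series

The compounds below may be only part of what the source reports. "The series", "measured", "known", "first", "only" and "open" are said of these compounds alone.

Of the compounds shown here, three from a common natural-product core have been tested in a functional assay on A549 cells (Homo sapiens) for cytotoxicity, read by MTT assay, with a stated time of 48 h; a lower number here means a stronger inhibitor, a higher number a weaker inhibitor. Compound 1, `CC(C)=CCC/C(C)=C/CC/C(C)=C/CC[C@@H]1[C@@]2(C)CCC(=O)C(C)(C)[C@@H]2CC[C@@]1(C)O`, is the bare ketone and gives 12000 nM. Compound 2, `CC(C)=CCC/C(C)=C/CC/C(C)=C/CC[C@@H]1[C@@]2(C)CC/C(=N\OCc3cn(-c4cccc(O)c4)nn3)C(C)(C)[C@@H]2CC[C@@]1(C)O`, carries a triazole-bearing oxime and gives 12800 nM. Compound 3, `CC(C)=CCC/C(C)=C/CC/C(C)=C/CC[C@@H]1[C@@]2(C)C/C(=C\c3ccc(OCc4cn(-c5ccccc5)nn4)cc3)C(=O)C(C)(C)[C@@H]2CC[C@@]1(C)O`, carries a benzylidene linked through an ether to a phenyl-substituted triazole, and gives 100000 nM. Among the three, compound 3 stands at the highest number, meaning the weakest inhibition, and its gap to compound 2 and to compound 1 lies beyond the usual scatter.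

Compound 4, `CC(C)=CCC/C(C)=C/CC/C(C)=C/CC[C@@H]1[C@@]2(C)C/C(=C\c3ccc(OCc4cn(-c5ccc(F)c(Cl)c5)nn4)cc3)C(=O)C(C)(C)[C@@H]2CC[C@@]1(C)O`, differs from compound 3 in one place: 3-chloro-4-fluorophenyl in place of phenyl on an aromatic nitrogen. Among the compounds with values here, no pair of measured compounds shows this kind of change, so there is nothing in hand to set its size or direction. With only this to go on, the step of a 1.5-fold lower number from compound 3 to compound 4 (0.19 log units; within the scatter) is expected to be modest and may not exceed the scatter. Compound 4 is therefore estimated at 65000 nM, within a range from 20000 nM to 150000 nM.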

Compound 4, half-maximal inhibitory concentration: 46600 nM
Estimate against measurement, compound 4: 1.4-fold (0.14 log units) above; measured number inside the range.
By their numbers in this assay, from the lowest: compounds 1 and 2 (each within the scatter of the next); then compound 4; then compound 3.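

In this assay, within the data shown here, the aryl group on the aromatic nitrogen of the five-membered ring with 3 nitrogen is the first place in this set where a single change can be read: 3-chloro-4-fluorophenyl in place of phenyl gives a 2.1-fold lower number from compound 3 to compound 4 (0.33 log units; beyond the scatter) on the same benzylidene framework. This shows that the number responds to a change at this position, though the step is modest and only just clears the usual scatter. There is no evidence here that explains the step.

As far as these compounds go, whether 3-chlorophenyl or 4-fluorophenyl alone would give a step of this size stays open, and so does the effect of an aminophenyl or a pyridine ring in the same place. Also open, from the compounds shown here alone, is whether the same swap would shift the number in the oxime-linked series of compound 2.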